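This account rests on a few compounds, and the source may have more. Where it says the series, first, only, none or still open, it means among the compounds named here.

Compound 1 has the structure `C/C(=C\c1cc(-c2ccc(C#N)cc2)cs1)C(N)=O`. In a functional assay on A549 cells (Homo sapiens) for cytotoxicity, read by CCK-8 assay, with a stated time of 24 h (on this read-out lower numbers stand for stronger inhibition and higher numbers for weaker inhibition), compound 1 gives > 50000 nM, which is a limit of the assay rather than a number.
Compound 2 has the structure `C/C(=C\c1cc(-c2ccc(S(C)(=O)=O)cc2)cs1)C(N)=O`. In this assay compound 2 gives > 50000 nM, again a limit of the assay.
Compound 3 has the structure `C/C(=C\c1cc(-c2ccc(C(F)(F)F)cc2)cs1)C(N)=O`. In this assay compound 3 gives > 50000 nM, once more a limit of the assay.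

So compound 3 stands nowhere in particular among the numbers shown: its value is only a limit, and the two other values are limits as well, all three sitting at the limit of > 50000 nM in this assay, at which 3 of the 3 values shown sit. The step from compound 1 to compound 3, a step that the two limits leave unreadable from compound 1 to compound 3, and the step from compound 2 to compound 3, a step that the two limits leave unreadable from compound 2 to compound 3, therefore give no readable size, and the same holds for a step that the two limits leave unreadable from compound 1 to compound 2.

Compound 4, `C/C(=C\c1cc(-c2ccc(Cl)cc2)cs1)C(N)=O`, differs from compound 3 by chloro in place of trifluoromethyl on an aromatic carbon. Among the compounds with values here, none of the measured steps shows a readable change in this assay, so no step beyond the scatter can be expected, and the step from compound 3 to compound 4 is estimated as a number no higher from compound 3 to compound 4 (the limit leaves the size open). Compound 4 is expected to give about 50000 nM in this assay, with a range from 15000 nM to 150000 nM, most likely reported again as a limit.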

Compound 4, half-maximal inhibitory concentration: > 50000 nM
Compound 4 ended at the assay's limit; the forecaster's own chance of this, stated with the estimate: 80%; the middle value sits exactly at the limit.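

In this assay the steps to compound 4 from compound 1, compound 2 and compound 3 cannot be read, because all four values are limits: the limit of > 50000 nM in this assay, at which 4 of the 4 values shown sit. The compounds shown leave open whether cyano, methylsulfonyl, trifluoromethyl or chloro on that aromatic carbon makes any difference to the read-out.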